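The source may hold more compounds than are shown below. What is called first, only, known or untested is meant among the compounds shown, and "the series" means these compounds.

Working notes on the series. For the measured compounds named here, compound 1 `O=C(/C(=C\c1ccc(Br)cc1)Sc1ccccc1Br)c1ccc(Br)cc1` is the only member with a number in a functional assay on DU-145 cells (Homo sapiens) for inhibition, read by trypan blue exclusion, with a stated time of 96 h; a lower number here means a stronger inhibitor of growth, a higher number a weaker inhibitor of growth: compound 1 gives 1000 nM. Compound 2 `CN(C)c1ccc(/C=C(/Sc2ccccc2Br)C(=O)c2ccc(Br)cc2)cc1` reaches only the limit of this assay, where compound 2 sits at > 100000 nM. The change bromo in place of dimethylamino on an aromatic carbon thus makes a step of an at least 100-fold lower number from compound 2 to compound 1 (2.00 log units; beyond the scatter), and that step is a lower bound only, due to the limit of > 100000 nM in this assay, at which 2 of the 3 values shown sit. Compound 3 `CN(C)c1ccc(/C=C(/Sc2ccc(Br)cc2)C(=O)c2ccc(Cl)cc2)cc1` likewise reaches only the limit of this assay, compound 3 giving > 100000 nM. The difference between the cores of compound 2 and compound 3 is not broken down here. Compound 4 `O=C(/C(=C\c1ccc(Br)cc1)Sc1ccc(Br)cc1)c1ccc(Cl)cc1` carries the same change as compound 1 does, (bromo in place of dimethylamino on an aromatic carbon), at a place worded identically. By analogy with the step to compound 1, a step of an at least 66-fold lower number from compound 3 to compound 4 (1.82 log units; beyond the scatter) is expected here, so compound 4 is estimated at 1500 nM, between 300 nM and 8000 nM.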

Compound 4, concentration for 50% growth inhibition: 1000 nM
For compound 4 the middle estimate is 1.5-fold (0.18 log units) above the measured one; the measured number falls inside the stated range.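

In this assay, the change from 4-(dimethylamino)phenyl to 4-bromophenyl carries over to a second core, giving an at least 100-fold lower number from compound 3 to compound 4 (2.00 log units; beyond the scatter). The two steps run the same way and both are large, so on these two cores the change goes with a lower number: the same change on two cores in this assay, an at least 100-fold lower number (2.00 log units; beyond the scatter) from compound 2 to compound 1 and an at least 100-fold lower number (2.00 log units; beyond the scatter) from compound 3 to compound 4; the limit leaves it open whether they differ. The true size of each step stays unread, and no difference between the cores can be claimed, due to the assay limit: the limit of > 100000 nM in this assay, at which 2 of the 4 values shown sit.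

Open, as far as these compounds go, is whether the step recurs on any core beyond these two. Also open, from the compounds shown here alone, is where a group such as methoxy, a primary amine or a carboxylic acid at this place would fall relative to the bromo and dimethylamino compounds.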